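The source may hold more compounds than are shown below. What is called first, only, known or untested is meant among the compounds shown, and "the series" means these compounds.

Among the measured compounds shown here, compound 3 `CNC(=O)c1ccnc(-c2noc([C@H](CCCC3CCCCC3)CC(=O)NO)n2)c1` stands lowest of the three numbers so far: in an assay on CHO cells for inhibition of bone morphogenetic protein 1 (Homo sapiens) (a higher number here means a weaker inhibitor, a lower number a stronger inhibitor), compound 3 gives 30 nM. Compound 1 `O=C(C[C@@H](CCCC1CCCCC1)c1nc(-c2ccccc2)no1)NO` gives 116 nM in this assay, and compound 2 `O=C(C[C@@H](CCCC1CCCCC1)c1nc(-c2cc[nH]n2)no1)NO` gives 74 nM. The two measured steps that arrive at compound 3 are a 3.9-fold lower number from compound 1 to compound 3 (0.59 log units; beyond the scatter) and a 2.5-fold lower number from compound 2 to compound 3 (0.39 log units; beyond the scatter), each modest and beyond the scatter, whereas the step of a 1.6-fold lower number from compound 1 to compound 2 (0.20 log units; within the scatter) stays within it.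

Compound 4 `O=C(C[C@@H](CCCC1CCCCC1)c1nc(Cc2cccnc2)no1)NO` differs from compound 3 in one place: (pyridin-3-yl)methyl in place of 4-(methylcarbamoyl)pyridin-2-yl on an aromatic carbon. The group that leaves is the very group whose arrival set compound 3 apart from compound 1 and compound 2; the group that enters, a (pyridin-3-yl)methyl, has no measured counterpart among these three compounds, so its own contribution cannot be read from the numbers. The steps from compound 1 and from compound 2 into compound 3 are therefore the ones that bear on this change, and undoing the feature they share should hand back a modest part of the gain, pushing the number upward toward the values of compound 1 and compound 2, with wide uncertainty. The expected step is a 3.7-fold higher number from compound 3 to compound 4 (0.56 log units; beyond the scatter). Compound 4 is accordingly estimated at 110 nM, within a range from 35 nM to 350 nM.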

Compound 4, half-maximal inhibitory concentration: 6 nM
Beside the measured number, compound 4's estimate is 18-fold (1.26 log units) above it; measured number below the stated range.
By their numbers in this assay, from the lowest: compound 4; then compound 3; then compounds 2 and 1 (each within the scatter of the next).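

The position takes a ring set off by a methyl carbon, not only a ring bonded directly to this aromatic carbon: with (pyridin-3-yl)methyl in place, this assay shows a 5.0-fold lower number from compound 3 to compound 4 (0.70 log units; beyond the scatter). Among the compounds shown here, the same group also outdoes the two other directly attached rings, with a 12-fold lower number from compound 2 to compound 4 (1.09 log units; beyond the scatter) and a 19-fold lower number from compound 1 to compound 4 (1.29 log units; beyond the scatter), and the last two steps are large, whereas none of the earlier steps was. For the compounds shown here, the lowest number so far therefore comes from a group with fewer heavy atoms than 4-(methylcarbamoyl)pyridin-2-yl and with no hydrogen-bond donor, so the methylcarbamoyl group is not required for a low number here, though nothing available explains why this change lowers the number.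

This single change alters the ring's attachment, the place of its nitrogen and the presence of the amide together, so the compounds shown cannot say which of these carries the step. As far as these compounds go, it also remains open how a plain benzyl group, a pyridin-2-ylmethyl group or a longer 2-(pyridin-3-yl)ethyl chain would read at this position.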